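The compounds below may be only part of what the source reports. "The series", "measured", "known", "first", "only" and "open" are said of these compounds alone.

Working notes on the series

The shared core, seen in compound 1 `CCCCNc1nc(N)nc2c1CN(S(C)(=O)=O)CC2`, carries on its ring amine nitrogen a methylsulfonyl group; in an assay on HEK293 cells for agonist activity at Toll-like receptor 8 (Homo sapiens), read by a luciferase reporter, with a stated time of 6 h (on this read-out higher numbers stand for an effect only at larger amounts of compound and lower numbers for an effect already at smaller amounts), compound 1 gives 9.9 uM. Compound 2 `CCCCNc1nc(N)nc2c1CN(C(=O)CC)CC2`, with propanoyl at that position, gives 0.4 uM in this assay, and compound 3 `CCCCNc1nc(N)nc2c1CN(C(=O)C(C)C)CC2`, with isopropylcarbonyl, gives 1.6 uM. The steps are a 25-fold lower number from compound 1 to compound 2 (1.39 log units; beyond the scatter) and a 6.2-fold lower number from compound 1 to compound 3 (0.79 log units; beyond the scatter), so both acyl groups move the number well below that of compound 1; the step of a 4.0-fold higher number from compound 2 to compound 3 (0.60 log units; beyond the scatter) sets compound 3 second highest of the three numbers, nearest to compound 2 and furthest from compound 1.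

Compound 4 `CCCCNc1nc(N)nc2c1CN(C(=O)c1csc(C)n1)CC2` is not yet measured. It differs from compound 3 by 2-methyl-1,3-thiazol-4-yl in place of isopropyl on a carbonyl carbon. Among the measured compounds shown here, no measured step replaces an alkyl group on the carbonyl carbon with an aromatic ring; the measured steps only show that an acyl group at this position beats methylsulfonyl and that the branched isopropylcarbonyl trails propanoyl. The branching of isopropyl is removed, but a larger ring enters, so no step beyond the scatter is expected in this assay, with the estimated change written as a 1.6-fold lower number from compound 3 to compound 4 (0.20 log units; within the scatter). Compound 4 is estimated at 1 uM in this assay, within 0.25 uM to 4 uM.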

Compound 4, minimum effective concentration: 1.8 uM
Beside the measured number, compound 4's estimate is 1.8-fold (0.26 log units) below it; low and high end bracket the measured number.
By their numbers in this assay, from the lowest: compound 2; then compounds 3 and 4 (each within the scatter of the next); then compound 1.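

With a 1.1-fold higher number from compound 3 to compound 4 (0.05 log units; within the scatter) in this assay, the carbonyl carbon accepts 2-methyl-1,3-thiazol-4-yl in place of isopropyl with no readable change, so an aromatic ring at this place is tolerated as well as a branched alkyl group. The step of a 4.5-fold higher number from compound 2 to compound 4 (0.65 log units; beyond the scatter) leaves propanoyl in compound 2 with the lowest number of the four, since the thiazole amide does not reach it. The step of a 5.5-fold lower number from compound 1 to compound 4 (0.74 log units; beyond the scatter) shows that the advantage of a carbonyl group over methylsulfonyl on the ring nitrogen extends from alkyl acyl groups to one bearing an aromatic ring.

Open, as far as these compounds go, is whether acetyl, butanoyl or an unsubstituted phenyl on the carbonyl carbon would keep or lower the number seen with propanoyl. Nothing shown bears on why these groups rank as they do.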